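Notes on a bromo-to-ethyl swap, compound 2 to compound 4

A few compounds are considered here, and "the series" means these few. Any claim that something is new, unique, unknown or untested is made for them only; others in the source may bear on it.

Measured so far:
compound 1 `CCOc1ccc(C(=O)/C=C/c2ccc(F)cc2)cc1` — 53 nM in an assay on isolated protein for inhibition of Amine oxidase [flavin-containing] B (Homo sapiens); a higher number here means a weaker inhibitor, a lower number a stronger inhibitor
compound 2 `CCOc1ccc(C(=O)/C=C/c2ccc(Br)cc2)cc1` — 210 nM in this assay
compound 3 `CC/C(C)=N/Oc1ccc(C(=O)/C=C/c2ccccc2)cc1` — 86 nM in this assay

Compound 2 gives the highest number of the three in this assay; the gap to compound 3 and the larger gap to compound 1 both lie beyond the usual scatter. For the measured compounds named here, the one single-point step measured is a 4.0-fold higher number from compound 1 to compound 2 (0.60 log units; beyond the scatter), a change at the same aromatic carbon that is now altered again.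

Compound 4 `CCOc1ccc(C(=O)/C=C/c2ccc(CC)cc2)cc1` differs from compound 2 by ethyl in place of bromo on an aromatic carbon. Going by the values given here, no measured compound carries an alkyl group at that place, so the halogen step is the only guide, and it speaks to size of effect rather than direction for an alkyl group. Halogen-to-alkyl swaps of this kind commonly move the number little. The working expectation is that compound 4 lands near compound 2, if anything somewhat lower: the estimate for compound 4 in this assay is 150 nM, range 50 nM to 450 nM. This estimate corresponds to an expected step of a 1.4-fold lower number from compound 2 to compound 4 (0.15 log units; within the scatter), not clearly beyond the scatter.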

Compound 4, half-maximal inhibitory concentration: 210 nM
Compound 4: the middle estimate sits 1.4-fold (0.15 log units) below what was measured, within the range that was stated.
By their numbers in this assay, from the lowest: compounds 1 and 3 (each within the scatter of the next); then compounds 2 and 4 (each within the scatter of the next).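

In this assay the step of no change at the digits printed from compound 2 to compound 4 (within the scatter) shows that ethyl and bromo cannot be told apart at this aromatic carbon, although they differ in kind and in heavy-atom count. Ethyl in place of fluoro gives a 4.0-fold higher number from compound 1 to compound 4 (0.60 log units; beyond the scatter) and so matches in size the step of a 4.0-fold higher number from compound 1 to compound 2 (0.60 log units; beyond the scatter), which leaves fluoro with the lowest number of the three groups tried at this carbon. Nothing available here accounts for ethyl and bromo reading alike or for fluoro standing apart.

Still open, from the compounds shown here alone, is whether an amine, a carboxylic acid or a longer chain such as butyl at this carbon would read with ethyl and bromo or with fluoro. The compounds shown also leave open whether the gap between fluoro and the other two groups holds when the rest of the shared core is changed.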